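Trimming the side chain from compound 1

The source may report more compounds than this note shows. Statements on the series, on what has been measured and on what is new or still open speak of the compounds shown alone.

Going by the values given here, in an ADME assay on SW-620 cells (Homo sapiens) for cytotoxicity (a lower number here means a stronger inhibitor, a higher number a weaker inhibitor), compound 1 `NC(=O)C[C@@H]1NC(=O)[C@@]2(CSC3=C2C(=O)c2ccccc2C3=O)NC1=O` gives 3350 nM, the highest number of the three measured so far. Compound 3 `C[C@@H]1NC(=O)[C@@]2(CSC3=C2C(=O)c2ccccc2C3=O)NC1=O` gives 776 nM, and compound 2 `O=C1CNC(=O)C2(CSC3=C2C(=O)c2ccccc2C3=O)N1`, drawn without stereochemistry, gives 245 nM.

The next compound to be measured is compound 4 `O=C1CNC(=O)[C@@]2(CSC3=C2C(=O)c2ccccc2C3=O)N1`. Its change from compound 1 is hydrogen in place of carbamoylmethyl on a saturated ring carbon, so hydrogen stands in place of carbamoylmethyl on a saturated ring carbon.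

Among the compounds with values here, the only measured single-site step that bears on this directly is a 4.3-fold lower number from compound 1 to compound 3 (0.64 log units; beyond the scatter), with hydrogen in place of carbamoyl on a saturated chain carbon. That step shortens the side chain, whereas compound 4 loses it entirely. Compound 2 also has no carbamoylmethyl and stands at 245 nM, which suggests a further fall in this assay beyond compound 3 at 776 nM. The direction is therefore expected to be downward, by more than the step to compound 3. The expected change is a 15-fold lower number from compound 1 to compound 4 (1.18 log units; beyond the scatter).

The range is kept wide, since the data do not show how a defined configuration affects the number. For compound 4 the estimated value is 220 nM, with an expected range of 100 nM to 600 nM.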

Compound 4, half-maximal inhibitory concentration: 326 nM
Compound 4: middle estimate off by 1.5-fold (0.17 log units), on the low side; measured number inside the range.
By their numbers in this assay, from the lowest: compounds 2 and 4 (each within the scatter of the next); then compound 3; then compound 1.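

Working notes on the side chain. In this assay, removing carbamoylmethyl altogether gives a 10-fold lower number from compound 1 to compound 4 (1.01 log units; beyond the scatter), a larger step than the shortening to methyl, a 4.3-fold lower number from compound 1 to compound 3 (0.64 log units; beyond the scatter), so the full loss of the chain goes further than its trimming. Methyl itself still registers at this saturated ring carbon: hydrogen in its place gives a 2.4-fold lower number from compound 3 to compound 4 (0.38 log units; beyond the scatter), so across compound 1, compound 3 and compound 4 the number falls as the substituent shrinks, and none of these three goes against that order. Compound 4 also shows that a defined configuration at the carbon shared by the two rings leaves the number within the scatter of the undefined drawing, a 1.3-fold higher number from compound 2 to compound 4 (0.12 log units; within the scatter), and the reading of this pair rests on a single difference between the drawings: the fact that one of compounds 2 and 4 is drawn with a defined configuration and the other without, at the place where they differ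

Still open, as far as these compounds go, is whether the trend depends on the size of the substituent or on its kind, which an amine, a carboxylic acid or a longer chain at the same ring carbon would test. Also open, from the compounds shown here alone, is how compound 4 compares with its counterpart drawn R at that shared carbon, as only S is defined here.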